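Methyl on a Fused Ring: What Compound 4 Might Show

A few compounds are considered here, and "the series" means these few. Any claim that something is new, unique, unknown or untested is made for them only; others in the source may bear on it.

Three amides that share one core have been measured in an in vitro functional assay on 1321-N1 cells for antagonist activity at transient receptor potential cation channel subfamily V member 1 (Homo sapiens), read by FLIPR and calcium flux; a lower number here means a less potent compound, a higher number a more potent compound, by a factor of ten per unit of this negative logarithm. Compound 1, `Cc1nc2ccc(NC(=O)c3ccc(-c4ccc(F)cc4)nc3C)cc2[nH]1`, gives 6. Compound 2, `Cc1nc(-c2ccc(F)cc2)ccc1C(=O)Nc1ccc2nc[nH]c2c1`, gives 7.2. Compound 3, `Cc1nc(-c2ccc(F)cc2)ccc1C(=O)Nc1ccc2cn[nH]c2c1`, gives 7.5. Compound 2 and compound 1 differ by methyl in place of hydrogen on an aromatic carbon, and that single change made a step of a number 1.20 log units lower from compound 2 to compound 1 (beyond the scatter). Compound 3 and compound 2 are built from the same atoms joined differently; the difference between the two cores is not broken down here. Compound 3 stands above compound 1 beyond the scatter, while compound 3 and compound 2 lie within the scatter of each other.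

Compound 4, `Cc1nc(-c2ccc(F)cc2)ccc1C(=O)Nc1ccc2c(C)n[nH]c2c1`, has not yet been measured in this assay. It differs from compound 3 by methyl in place of hydrogen on an aromatic carbon. Going by the values given here, this is the same kind of change as the one from compound 2 to compound 1, but not the same: there the methyl entered between two ring nitrogen atoms, whereas here it enters next to the ring nitrogen, two ring bonds from the ring nitrogen.

Among the compounds with values here, the only precedent is the drop of a number 1.20 log units lower from compound 2 to compound 1 (beyond the scatter), so a fall for compound 4 is expected, though a smaller one is estimated, since the place is not the same. Compound 4 is expected to give 6.8, with a likely range from 6 to 7.5. That means an expected step of a number 0.70 log units lower from compound 3 to compound 4 (beyond the scatter).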

Compound 4, negative logarithm of the antagonist equilibrium constant: 6.9
The estimate for compound 4 lay 0.10 log units below the measured number, within the range that was stated.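

In this assay, methyl in place of hydrogen on an aromatic carbon of the five-membered ring again lowers the number, and the new step is a number 0.60 log units lower from compound 3 to compound 4 (beyond the scatter). The change therefore carries over from one core to the other in direction, but not in size, since the two steps stand apart beyond the scatter: the same change on two cores in this assay, a number 1.20 log units lower (beyond the scatter) from compound 2 to compound 1 and a number 0.60 log units lower (beyond the scatter) from compound 3 to compound 4, 0.60 log units apart, beyond the scatter of two such steps What this does not show is why the size differs, since the two steps differ both in the core and in the place where the methyl enters, and the pairs shown cannot separate these two differences, nor do two steps establish what the same change would do on any further core in this series.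

The compounds shown leave open how a group other than methyl, such as ethyl, an amine or a nitrile, would compare on the same aromatic carbon of either core. They also leave open whether the step from hydrogen to methyl would keep its direction if the fluorine were replaced by chlorine or a methoxy group, as all four compounds carry that same fluorine.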